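Ether Change at the Shared Core of Compound 2

This account rests on a few compounds, and the source may have more. Where it says the series, first, only, none or still open, it means among the compounds named here.

For the measured compounds named here, compound 2 `CCOc1nc(-c2ccc(NS(=O)(=O)c3cc(Cl)ccc3F)cc2)nc2[nH]nc(C)c12` gives 183 nM in an assay for inhibition of serine/threonine-protein kinase Sgk1 (Homo sapiens), with stated times of 30 min and 60 min, in the presence of a further agent that is not named here (on this read-out higher numbers stand for weaker inhibition and lower numbers for stronger inhibition), the higher of the two numbers known, while compound 1 `CN1CCC(NC(=O)c2cc(-c3ccc(NS(=O)(=O)c4cccc(Cl)c4Cl)cc3)nc3[nH]ncc23)C1` gives 21 nM in this assay, a gap beyond the scatter. Compound 3 `Cc1n[nH]c2nc(-c3ccc(NS(=O)(=O)c4cc(Cl)ccc4F)cc3)nc(OC3CCOCC3)c12` differs from compound 2 by oxan-4-yl in place of ethyl on an oxygen on an aromatic ring. Going by the values given here, no measured pair shows this change, so only a modest step in either direction, if any beyond the scatter, is expected: a 1.2-fold lower number from compound 2 to compound 3 (0.09 log units; within the scatter). Compound 3 is therefore estimated at 150 nM, between 50 nM and 450 nM.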

Compound 3, half-maximal inhibitory concentration: 14 nM
Estimate against measurement, compound 3: 11-fold (1.03 log units) above; the measured number lies below the stated range.
By their numbers in this assay, from the lowest: compounds 3 and 1 (each within the scatter of the next); then compound 2.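

In this assay the group on this oxygen proves to matter: oxan-4-yl in place of ethyl gives a 13-fold lower number from compound 2 to compound 3 (1.12 log units; beyond the scatter) and so a large step beyond the scatter. For the compounds shown here, the earlier compounds offered no pair differing in one place, so this is the first sign that the position responds to what it carries. No measurement given here explains the step.

The compounds shown leave open whether the step comes from the oxygen of oxan-4-yl or from the ring itself, which cyclohexyl on the same oxygen would separate, and how a piperidin-4-yl group, with its amine, would fare there.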